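Adding an ethyl to the acid of compound 1

The compounds below may be only part of what the source reports. "The series", "measured", "known", "first", "only" and "open" are said of these compounds alone.

Among the measured compounds shown here, in a functional assay on the whole organism (strain Sprague-Dawley) for inhibition, with Rattus norvegicus as the target, with a stated time of 10 min (on this read-out higher numbers stand for an effect only at larger amounts of compound and lower numbers for an effect already at smaller amounts), compound 1 `O=C(O)c1cnc(-c2ccccc2F)[nH]c1=O` gives 5 mg/kg, and compound 2 `O=C(O)c1cnc(-c2ccccc2OCc2ccccc2)[nH]c1=O` gives 5 mg/kg, so the two stand level on the numbers so far. Compound 3 `CCOC(=O)c1cnc(-c2ccccc2F)[nH]c1=O` keeps the core of compound 1 and alters one place: ethyl in place of hydrogen on an oxygen next to a carbonyl group. Cut one bond further out, this reads carboxy to ethoxycarbonyl. For the measured compounds named here, the only measured step, no change at the digits printed from compound 1 to compound 2 (within the scatter), places benzyloxy in place of fluoro on an aromatic carbon, so it concerns a different part of the structure. Going by the values given here, no measured compound alters the carboxy group, so the data give no direct guide to this change and any expectation remains uncertain. A modest move toward a higher dose in this assay is expected, and the expected size is a 2.0-fold higher number from compound 1 to compound 3 (0.30 log units; within the scatter). For compound 3 the estimated dose is 10 mg/kg, with an expected range of 3 mg/kg to 35 mg/kg.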

Compound 3, dose for 50% inhibition: > 10 mg/kg
Compound 3 gave a limit, no number; the forecaster's own chance of this, stated with the estimate: 15%; the middle value lies on the limit itself.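

In this assay, compound 3 carries a limit and not a number: the limit of > 10 mg/kg in this assay, at which 1 of the 3 values shown sits. The change from carboxy to ethoxycarbonyl, ethyl in place of hydrogen on an oxygen next to a carbonyl group, reads as an at least 2.0-fold higher number from compound 1 to compound 3 (0.30 log units; that floor lies within the scatter). Among the compounds shown here, this is the first measured change at the carboxy group, since the earlier step only put benzyloxy in place of fluoro on an aromatic carbon, and its floor does not show that the free acid of compound 1 is needed.

From the compounds shown here alone, how far the true value of compound 3 lies beyond its limit stays open, so the size of this step remains unsettled. Also open, going by these compounds, is whether a methyl or a propyl on that oxygen, or an amide in place of the carboxy group, would read like the ethyl.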